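A few compounds are considered here, and "the series" means these few. Any claim that something is new, unique, unknown or untested is made for them only; others in the source may bear on it.

Compound 2 `COc1ccc(-c2cc(-c3ccccc3)no2)c(OCC(=O)O)c1` gives 11.7% in a functional assay on the whole organism (blood, strain Charles Foster/Wistar albino) with Rattus norvegicus as the target, with a stated time of 30 min, at a dose of 100 mg/kg by the oral route; a lower number here means less inhibition, a higher number more inhibition at the dose given (going by the name of the read-out); on the numbers in hand it stands together with compound 1 `COc1ccc(-c2cc(-c3ccccc3)no2)c(OCC(O)CN2CCCCC2)c1`, which gives 17%, the two within the scatter of each other, as shown by the step of a number 5.3 percentage points lower from compound 1 to compound 2 (within the scatter). Compound 3 `COc1ccc(-c2cc(-c3ccccc3)no2)c(O)c1` differs from compound 2 by hydrogen in place of carboxymethyl on an oxygen on an aromatic ring. Within the data shown here, the one measured step, a number 5.3 percentage points lower from compound 1 to compound 2 (within the scatter), altered the group on that same oxygen without moving the read-out beyond the scatter, so a similar outcome is expected here: a number 1.3 percentage points higher from compound 2 to compound 3 (within the scatter). Compound 3 is therefore estimated at 13%, in a range from 3% to 25%.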

Compound 3, a percentage reported as inhibition, in the whole organism at one dose (the size of the read-out at that dose, not a potency): 9.8%
The estimate for compound 3 lay 3.2 percentage points above the measured number, and the stated range covers the measured number.
By their numbers in this assay, from the lowest: compounds 3, 2 and 1 (each within the scatter of the next).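

In this assay, replacing the group on the oxygen on the aromatic ring with hydrogen gives a number 1.9 percentage points lower from compound 2 to compound 3 (within the scatter) and a number 7.2 percentage points lower from compound 1 to compound 3 (within the scatter). Neither carboxymethyl nor 2-hydroxy-3-(piperidin-1-yl)propyl on this oxygen is therefore set apart from the plain hydroxy, and this holds for both an acid-bearing and an amine-bearing chain. Nothing at hand gives a reason for this result. Going by these compounds, it remains open whether a methyl ether, an ester of the carboxylic acid or a morpholine in place of the piperidine would move the read-out beyond the scatter. Changes on the shared core away from this oxygen also remain open.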